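Trimming a branched side chain: compound 3 to compound 4

This account rests on a few compounds, and the source may have more. Where it says the series, first, only, none or still open, it means among the compounds named here.

Measured so far:
- compound 1, `CC(=O)c1ccc(NC(=O)CN(C(=O)c2ccccc2)S(=O)(=O)c2ccc([N+](=O)[O-])cc2)cc1`, 20.6%
- compound 2, `CC(=O)c1ccc(NC(=O)C(CC(C)C)N(C(=O)c2ccccc2)S(=O)(=O)c2ccc([N+](=O)[O-])cc2)cc1`, 62.3%
- compound 3, `CCC(C)C(C(=O)Nc1ccc(C(C)=O)cc1)N(C(=O)c1ccccc1)S(=O)(=O)c1ccc([N+](=O)[O-])cc1`, 42.1%

All three share one core and differ only in the group on the saturated chain carbon bound to an amide-type nitrogen and a carbonyl carbon. In a functional assay for inhibition, read by spectrophotometry, with a stated time of 20 min, tested at 3 mg/mL (on this read-out higher numbers stand for a stronger effect at the one concentration tested and lower numbers for a weaker effect), compound 3 gives 42.1%, the second highest of the three numbers; compound 2 lies above it, a number 20.2 percentage points lower from compound 2 to compound 3 (beyond the scatter), and compound 1 lies below it, a number 21.5 percentage points higher from compound 1 to compound 3 (beyond the scatter).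

Compound 4, `CC(=O)c1ccc(NC(=O)C(C(C)C)N(C(=O)c2ccccc2)S(=O)(=O)c2ccc([N+](=O)[O-])cc2)cc1`, has not yet been measured. It differs from compound 3 in one place: hydrogen in place of methyl on a saturated chain carbon, three bonds along the chain from an amide-type nitrogen and a carbonyl carbon.

Among the measured compounds shown here, the steps that bear on this are those that build up the side chain from hydrogen. Going from hydrogen to sec-butyl gave a number 21.5 percentage points higher from compound 1 to compound 3 (beyond the scatter), and going from hydrogen to isobutyl gave a number 41.7 percentage points higher from compound 1 to compound 2 (beyond the scatter). Compound 4 keeps a branched chain but a shorter one than compound 3, so the step is expected to undo only part of the gain seen between compound 1 and compound 3, a modest drop or perhaps nothing beyond the scatter, a number 7.1 percentage points lower from compound 3 to compound 4 (within the scatter). Compound 4 is therefore estimated to give 35% in this assay, within a range from 20% to 52%.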

Compound 4, a percentage reported as inhibition, at one concentration (the size of the read-out at that concentration, not a potency): 29.8%
Beside the measured number, compound 4's estimate is 5.2 percentage points above it; low and high end bracket the measured number.
By their numbers in this assay, from the lowest: compounds 1 and 4 (each within the scatter of the next); then compound 3; then compound 2.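

In this assay, the loss of a single methyl, which turns sec-butyl into isopropyl, is a step that can be read (a number 12.3 percentage points lower from compound 3 to compound 4 (beyond the scatter)), so even this small trim of the side chain registers at this position. Compound 4 also shows that a branched group on the saturated chain carbon bound to an amide-type nitrogen and a carbonyl carbon is not enough on its own: isopropyl does not separate clearly from hydrogen (a number 9.2 percentage points higher from compound 1 to compound 4 (within the scatter)), while isobutyl and isopropyl, which share a branch point but differ in where it sits and in size, stand far apart (a number 32.5 percentage points lower from compound 2 to compound 4 (beyond the scatter)). Nothing available explains why these side chains rank as they do.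

The compounds shown leave open how an unbranched chain such as n-butyl, or a benzyl group, would read at this carbon, and so whether isobutyl marks a peak or just one point on a rising series. Also open, on these data alone, is how a side chain ending in an amine or a carboxylic acid would compare with these purely hydrocarbon groups.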